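A few compounds are considered here, and "the series" means these few. Any claim that something is new, unique, unknown or untested is made for them only; others in the source may bear on it.

Measured so far in an ADME assay on A549 cells (Homo sapiens) for cytotoxicity, read by CellTiter-Glo; on this read-out lower numbers stand for higher toxicity in this test and higher numbers for lower toxicity in this test:
- compound 1 `Cc1c(Cc2ccc(Cl)cc2)c(=O)oc2cc(OCC(O)CN3CCC(C(N)=O)CC3)ccc12`: 40000 nM
- compound 2 `COC(=O)c1ccc(Cc2c(C)c3ccc(OCC(O)CN4CCC(C(N)=O)CC4)cc3oc2=O)cc1`: a limit of the assay, > 100000 nM
- compound 3 `Cc1noc(C)c1-c1ccc(Cc2c(C)c3ccc(OCC(O)CN4CCC(C(N)=O)CC4)cc3oc2=O)cc1`: 36900 nM

Compound 3 holds the lowest of the two numbers in this assay, with compound 1 nearest; the gap between them, a 1.1-fold lower number from compound 1 to compound 3 (0.04 log units; within the scatter), lies within the scatter. The value of compound 2 is a limit only (the limit of > 100000 nM in this assay, at which 1 of the 3 values shown sits). Against it, an at least 2.7-fold lower number from compound 2 to compound 3 (0.43 log units; beyond the scatter) and an at least 2.5-fold higher number from compound 1 to compound 2 (0.39 log units; beyond the scatter) are both beyond the scatter.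

Compound 4 `Cc1c(Cc2ccc(-c3ccc(Cl)cc3)cc2)c(=O)oc2cc(OCC(O)CN3CCC(C(N)=O)CC3)ccc12` differs from compound 3 by 4-chlorophenyl in place of 3,5-dimethyl-1,2-oxazol-4-yl on an aromatic carbon. The steps that touch the group leaving are those of compound 3 itself: its pairing with compound 1, within the scatter, and with compound 2, beyond it. Among the measured compounds shown here, no measured step brings in the group entering, so the closest guide is the flat result between a chloro substituent and the dimethyl-oxazole. The step of a 1.1-fold lower number from compound 3 to compound 4 (0.02 log units; within the scatter) is therefore expected to stay within the scatter, with no direction claimed. For compound 4 in this assay the estimate is 35000 nM, between 12000 nM and 100000 nM.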

Compound 4, half-maximal cytotoxic concentration: 32900 nM
Compound 4: the middle estimate sits 1.1-fold (0.03 log units) above what was measured; the range from low to high includes it.
By their numbers in this assay, from the lowest: compounds 4, 3 and 1 (each within the scatter of the next). At a limit, above all of these: compound 2.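

At this aromatic carbon, para to a large group, 4-chlorophenyl, with no hydrogen-bond acceptors, cannot be told apart in this assay from either 3,5-dimethyl-1,2-oxazol-4-yl, with its two acceptors, or chloro: a 1.1-fold lower number from compound 3 to compound 4 (0.05 log units; within the scatter), and a 1.2-fold lower number from compound 1 to compound 4 (0.08 log units; within the scatter). Among the four compounds, only methoxycarbonyl stands apart, and the new compound extends that gap to a third substituent: an at least 3.0-fold lower number from compound 2 to compound 4 (0.48 log units; beyond the scatter). The value of compound 2 is a limit of the assay, not a number: the limit of > 100000 nM in this assay, at which 1 of the 4 values shown sits.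

On these data alone, it remains open whether a carboxylic acid or a primary amine at this carbon would group with methoxycarbonyl or with the other three substituents. Also open, as far as these compounds go, is whether the flat result holds when the shared core is changed elsewhere.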